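The source may report more compounds than this note shows. Statements on the series, on what has been measured and on what is new or still open speak of the compounds shown alone.

Of the compounds shown here, two have so far been measured in an assay on CHO cells for displacement of a labelled ligand from histamine receptor H3 (Macaca mulatta), read by scintillation counting, with a stated time of 1 h; on this read-out higher numbers stand for weaker inhibition and lower numbers for stronger inhibition. Compound 1 `Cc1cc(NC(=O)Nc2cc(Cl)cc(Cl)c2)ccc1N1CCC(N2CCCC2C)C1` gives 43 nM, and compound 2 `Cc1cc(NC(=O)NC2CCCCC2)ccc1N1CCC(N2CCCC2C)C1` gives 11.2 nM. For the measured compounds named here, the one step between them, a 3.8-fold lower number from compound 1 to compound 2 (0.58 log units; beyond the scatter), shows that the group on the amide-type nitrogen can be exchanged with a clear effect. On the numbers shown, compound 2 stands lowest of the two, with compound 1 as its only neighbour at the higher number. Compound 3 `Cc1cc(NC(=O)N2CCN(C)CC2)ccc1N1CCC(N2CCCC2C)C1` differs from compound 2 in one place: 4-methylpiperazin-1-yl in place of cyclohexylamino on a carbonyl carbon. The measured step touches the same part of the molecule but swaps one ring for another, whereas here the ring and the amide-type nitrogen are both replaced, so that step offers only loose guidance. A modest rise in the number is expected, a step of a 2.7-fold higher number from compound 2 to compound 3 (0.43 log units; beyond the scatter). Compound 3 is therefore estimated at 30 nM in this assay, with a likely range from 8 nM to 120 nM.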

Compound 3, inhibition constant: 12.7 nM
The estimate for compound 3 lay 2.4-fold (0.37 log units) above the measured number; the range from low to high includes it.
By their numbers in this assay, from the lowest: compounds 2 and 3 (each within the scatter of the next); then compound 1.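

In this assay, 4-methylpiperazin-1-yl in place of cyclohexylamino on the carbonyl carbon gives a 1.1-fold higher number from compound 2 to compound 3 (0.05 log units; within the scatter), so this position tolerates the loss of the amide hydrogen and the arrival of a second ring nitrogen without a change that can be read. The other new step, a 3.4-fold lower number from compound 1 to compound 3 (0.53 log units; beyond the scatter), places compound 1 apart from both compounds with a non-aromatic ring at this position, although three compounds are too few to make this a general rule. Nothing shown explains why the two groups give such similar numbers.

It remains open whether a ring is needed here at all, since a small open-chain amine such as dimethylamino on the carbonyl carbon does not appear among these compounds. A morpholine ring or a piperazine without the methyl group would also show whether the second ring nitrogen and its methyl group matter.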